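A few compounds are considered here, and "the series" means these few. Any claim that something is new, unique, unknown or untested is made for them only; others in the source may bear on it.

Measured compounds:
Compound 1, `CC(=O)c1ccc(Nc2ccnc(SCC(=O)c3ccc(Br)cc3)n2)cc1`, in a functional assay on A549 cells (Homo sapiens) for inhibition, read by sulforhodamine B assay, with a stated time of 48 h, tested at 10 uM (on this read-out lower numbers stand for less inhibition of growth and higher numbers for more inhibition of growth at the one concentration tested), gives 10%.
Compound 2, `CCOC(=O)c1ccc(Nc2ccnc(SCC(=O)c3ccc(C#N)cc3)n2)cc1`, in this assay gives 39%.

Among the two numbers measured in this assay, compound 1 stands lowest; compound 2 lies higher, and the gap between them is beyond the scatter. The two compounds differ in more than one place, so nothing can be read from that pair about any single change. Compound 3, `CC(=O)c1ccc(Nc2ccnc(SCC(=O)c3ccc(-c4ccccc4)cc3)n2)cc1`, has not yet been measured. It differs from compound 1 by phenyl in place of bromo on an aromatic carbon. For the measured compounds named here, no measured pair shows this change on its own, and the data give no step to lean on. The expected step is therefore a small one, a number 8 percentage points higher from compound 1 to compound 3 (within the scatter), pointing slightly upward but not clearly beyond the scatter. On this basis compound 3 is expected to give 18% in this assay, within a range from 0% to 45%.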

Compound 3, percent growth inhibition at one concentration: 20%
Compound 3: middle estimate off by 2 percentage points, on the low side; the range from low to high includes it.
By their numbers in this assay, from the lowest: compounds 1 and 3 (each within the scatter of the next); then compound 2.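

In this assay, for the compounds shown here, the first step that can be read at this position is a number 10 percentage points higher from compound 1 to compound 3 (within the scatter), for phenyl in place of bromo on an aromatic carbon, para to a large group. Exchanging a single bromine for 6 heavy atoms and a six-membered aromatic ring therefore leaves the read-out with no difference beyond the scatter, in this one pair on the core of compound 1. No measurement of any other kind is at hand that bears on this result.

Going by these compounds, whether an amine, a carboxylic acid or a longer chain at the same position would shift the read-out beyond the scatter remains open. Going by these compounds alone, also open is whether the ethyl ester or the nitrile of compound 2 goes with its higher number, as no pair shows either change alone.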